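This account rests on a few compounds, and the source may have more. Where it says the series, first, only, none or still open, it means among the compounds named here.

Compound 1: `C=CCn1c(=O)/c(=C\c2cccc(F)c2)[nH]c(=O)/c1=C\c1ccccc1OC`; in a functional assay on BGC-823 cells (Homo sapiens) for cytotoxicity, read by CCK-8 assay, with a stated time of 72 h (a lower number here means a stronger inhibitor, a higher number a weaker inhibitor), compound 1 gives 5600 nM.
Compound 2: `C=CCn1c(=O)/c(=C\c2cccc(Cl)c2Cl)[nH]c(=O)/c1=C\c1ccccc1OC`; compound 2 gives 2200 nM.

Within the data shown here, compound 2 has the lowest of these two numbers; its only neighbour is compound 1, reached by a 2.5-fold lower number from compound 1 to compound 2 (0.41 log units; beyond the scatter). Compound 3 is `C=CCn1c(=O)/c(=C\c2ccc(F)c(Br)c2)[nH]c(=O)/c1=C\c1ccccc1OC`; it differs from compound 2 by 3-bromo-4-fluorophenyl in place of 2,3-dichlorophenyl on a double-bonded chain carbon bound to an aromatic carbon. Among the measured compounds shown here, the one measured step bearing on this change is a 2.5-fold lower number from compound 1 to compound 2 (0.41 log units; beyond the scatter), a modest shift when one halogen pattern on that ring replaced another, so a change of similar size in either direction, or none beyond the scatter, is plausible. Compound 3 is expected to give about 3000 nM (range 1200 nM to 8000 nM), an expected step of a 1.4-fold higher number from compound 2 to compound 3 (0.13 log units; within the scatter).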

Compound 3, half-maximal inhibitory concentration: "not active" (no number reported)
Compound 3 has no reported number here; the estimate stays without a comparison.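

Among these compounds, compound 3 is reported as "not active" without a number, so no step from compound 2 to compound 3 can be read. How far 3-bromo-4-fluorophenyl shifts the number remains open, and nothing shown explains the result.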